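Removing the methyl from compound 2

The compounds below may be only part of what the source reports. "The series", "measured", "known", "first", "only" and "open" are said of these compounds alone.

Measured in a functional assay on 786-0 cells (Homo sapiens); a lower number here means a stronger inhibitor of growth, a higher number a weaker inhibitor of growth
Compound 1 `COc1ccc(-c2cc(O)c3c(C)cc(C)nc3n2)cc1` gives 58900 nM
Compound 2 `COc1cccc(-c2cc(O)c3cc(C)cnc3n2)c1` gives 37.2 nM
Compound 3 `COc1ccc(-c2cc(O)c3ccc(C)nc3n2)cc1` gives > 100000 nM (a limit of the assay, not a number)

Compound 2 with 37.2 nM holds the lower of the two actual numbers in this assay, and compound 1 stands at 58900 nM in comparison. Compound 4 `COc1cccc(-c2cc(O)c3cccnc3n2)c1` follows from compound 2 by hydrogen in place of methyl on an aromatic carbon. Going by these compounds, the same kind of change has been measured only once, as an at least 1.6-fold higher number from compound 1 to compound 3 (0.22 log units; that floor lies within the scatter), and that step stays open-ended because of the limit of > 100000 nM in this assay, at which 1 of the 3 values shown sits. It starts from a far higher number than that of compound 2, so it offers only weak guidance on size. A modest rise in the number is therefore expected, with a wide margin. The expected change is a 4.0-fold higher number from compound 2 to compound 4 (0.61 log units; beyond the scatter) as estimated here. Compound 4 is estimated at 150 nM, with an expected range from 20 nM to 5000 nM.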

Compound 4, concentration for 50% growth inhibition: 61.7 nM
Compound 4: the middle estimate sits 2.4-fold (0.39 log units) above what was measured, and the stated range covers the measured number.
By their numbers in this assay, from the lowest: compounds 2 and 4 (each within the scatter of the next); then compound 1. At a limit, above all of these: compound 3.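

In this assay, going by these compounds alone, hydrogen in place of methyl on this aromatic carbon, two atoms from the ring nitrogen, gives a 1.7-fold higher number from compound 2 to compound 4 (0.22 log units; within the scatter), the first reading of this change with an actual number at both ends. On this core the methyl is therefore not required for a low number, as compound 4 gives 61.7 nM, within the scatter of compound 2. The earlier step ends at a limit of the assay, so the two steps can be set side by side only with one end open: the same change on two cores in this assay, an at least 1.6-fold higher number (0.22 log units; that floor lies within the scatter) from compound 1 to compound 3 and a 1.7-fold higher number (0.22 log units; within the scatter) from compound 2 to compound 4; the limit leaves it open whether they differ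

The compounds shown leave open whether a larger or different group at this position, such as an ethyl group, a methoxy group or an amine, would move the number beyond the scatter. Going by these compounds, whether the change stays this small on further cores also remains open.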